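The source may report more compounds than this note shows. Statements on the series, on what has been measured and on what is new or still open speak of the compounds shown alone.

Measured so far:
- compound 1, `O=C(O)c1cn(C2CC2)c2cc(N3CCN(C(=O)CN4CCN(C(c5ccccc5)c5ccccc5)CC4)CC3)c(F)cc2c1=O`: 25.9%
- compound 2, `Cc1cccc(N2CCN(CC(=O)N3CCN(c4cc5c(cc4F)c(=O)c(C(=O)O)cn5C4CC4)CC3)CC2)c1`: 16.2%

The series was tested in an ADME assay on RAW264.7 cells (Mus musculus) for cytotoxicity, read by MTT assay, with a stated time of 72 h, tested at 50 uM; on this read-out lower numbers stand for less inhibition and higher numbers for more inhibition at the one concentration tested (going by the name of the read-out). Compound 2 gives 16.2%, the lowest of the two numbers, while compound 1 gives 25.9%; the two values lie within the usual scatter of each other, so no order between them can be claimed.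

Compound 3, `CC(c1ccccc1)N1CCN(CC(=O)N2CCN(c3cc4c(cc3F)c(=O)c(C(=O)O)cn4C3CC3)CC2)CC1`, has not yet been measured in this assay. It differs from compound 2 in one place: 1-phenylethyl in place of 3-methylphenyl on an amine nitrogen in a ring. Going by the values given here, no step between measured compounds with a single change of this kind is available, so the expectation rests on the two values alone. With the neighbouring compound 1 at 25.9% and compound 2 at 16.2%, both low, the step of a number 3.8 percentage points higher from compound 2 to compound 3 (within the scatter) is expected to be small and not beyond the scatter. Compound 3 is therefore expected to give about 20%, somewhere between 8% and 34%.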

Compound 3, a percentage reported as inhibition, at one concentration (the size of the read-out at that concentration, not a potency): 16.9%
Compound 3: the middle estimate sits 3.1 percentage points above what was measured; low and high end bracket the measured number.
By their numbers in this assay, from the lowest: compounds 2, 3 and 1 (each within the scatter of the next).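

In this assay, 1-phenylethyl in place of 3-methylphenyl on the amine nitrogen in a ring gives a number 0.7 percentage points higher from compound 2 to compound 3 (within the scatter), so moving from an aryl group on this nitrogen to a saturated chain carbon that bears the phenyl shows no readable change. Methyl in place of phenyl on that saturated chain carbon gives a number 9 percentage points lower from compound 1 to compound 3 (within the scatter), so this change also stays within the usual scatter. At this position, neither single change separates the compounds it connects, and nothing measured here bears on the reason for this result.

On these data alone, it remains open whether a carboxylic acid or an amine on the phenyl ring would shift the number beyond the scatter in this assay at the one concentration tested. As far as these compounds go, a longer chain in place of the methyl on the saturated chain carbon is equally open.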